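The source may report more compounds than this note shows. Statements on the series, on what has been measured and on what is new or still open speak of the compounds shown alone.

Measured so far:
- compound 1, `CCOc1ccc2oc(/C=C/[S+](C)[O-])cc(=O)c2c1`: 4900 nM
- compound 2, `Cc1ccc2oc(/C=C/[S+](C)[O-])cc(=O)c2c1`: 7000 nM
- compound 3, `CC(C)Oc1ccc2oc(/C=C/[S+](C)[O-])cc(=O)c2c1`: 8000 nM

All three were tested in a functional assay on DLD-1 cells (Homo sapiens) for cytotoxicity, with a stated time of 48 h; a lower number here means a stronger inhibitor, a higher number a weaker inhibitor. Compound 1 gives the smallest of the three numbers, yet it is not set apart from the others: a 1.4-fold higher number from compound 1 to compound 2 (0.15 log units; within the scatter) and a 1.6-fold higher number from compound 1 to compound 3 (0.21 log units; within the scatter) are both within the scatter, and so is a 1.1-fold higher number from compound 2 to compound 3 (0.06 log units; within the scatter). The three compounds share one core and differ only in the group on one aromatic carbon, and none of those changes moved the number beyond what repeated measurements would give.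

Compound 4, `C[S+]([O-])/C=C/c1cc(=O)c2cc(OC(=O)C(C)(C)C)ccc2o1`, changes the same place once more: (tert-butyl)carbonyl in place of ethyl on an oxygen on an aromatic ring. For the measured compounds named here, the steps that bear on this are the ones just named, since each of them also swaps the group at that position, and each of them was small. The entering group is larger than anything tried so far and brings a carbonyl, so the measured steps do not cover it closely, but nothing among them points to a large move in either direction. The expected step is therefore a 1.3-fold higher number from compound 1 to compound 4 (0.12 log units; within the scatter), with a wide range to allow for the untested group. Compound 4 is expected to give 6500 nM, somewhere between 2500 nM and 17000 nM.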

Compound 4, half-maximal inhibitory concentration: 8000 nM
Beside the measured number, compound 4's estimate is 1.2-fold (0.09 log units) below it; the range from low to high includes it.
By their numbers in this assay, from the lowest: compounds 1, 2, 3 and 4 (each within the scatter of the next).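

In this assay, putting (tert-butyl)carbonyl in place of ethyl on this oxygen gives a 1.6-fold higher number from compound 1 to compound 4 (0.21 log units; within the scatter). For the compounds shown here, this is a much bigger change than any seen in the earlier compounds: the entering group has 6 heavy atoms against 2 for ethyl, and it adds a carbonyl and a hydrogen-bond acceptor, yet the comparisons with the other two compounds are just as flat, with no change at the digits printed from compound 3 to compound 4 (within the scatter) and a 1.1-fold higher number from compound 2 to compound 4 (0.06 log units; within the scatter). So across the four groups shown, neither the larger size nor the added carbonyl separates compound 4 from the others, and nothing measured here accounts for how little the number moves.

The compounds shown leave open whether any group at this place can move the number beyond the scatter, for example an amine, a carboxylic acid or a longer chain on the oxygen. How the number responds to a change elsewhere on the shared core also remains an open question.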